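From bromo to methyl: working notes on compound 4

The source may hold more compounds than are shown below. What is called first, only, known or untested is meant among the compounds shown, and "the series" means these compounds.

Values so far in a functional assay on HepG2 cells (Homo sapiens) for antiproliferative activity, read by CCK-8 assay, with a stated time of 72 h (on this read-out lower numbers stand for stronger inhibition and higher numbers for weaker inhibition), are as follows:
compound 1 `Nc1ccccc1NC(=O)c1ccc(COc2ccc(Br)cc2)cc1` gives > 32000 nM as a limit
compound 2 `O=C(/C=C/c1ccc(CN2CCc3ccccc32)cc1)NO` gives 14900 nM as a number
compound 3 `O=C(NO)c1ccc(COc2ccccc2)cc1` gives 29600 nM as a number

Compound 1 stands at > 32000 nM in this assay, which is a limit and not a number. Compound 2 and compound 3 both read out as numbers, and neither differs from any other measured compound in one place only.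

Compound 4 `Cc1ccc(OCc2ccc(C(=O)Nc3ccccc3N)cc2)cc1` has not yet been measured. It differs from compound 1 by methyl in place of bromo on an aromatic carbon, with methyl in place of bromo on an aromatic carbon, para to a large group. Among the measured compounds shown here, no measured pair shows what this exchange does, so the expectation rests on compound 1 alone and on the exchange being confined to one place. No step beyond the scatter is expected in this assay, and compound 4 is expected to stay weak. The expected outcome is an at least 1.0-fold lower number from compound 1 to compound 4 (0.02 log units; that floor lies within the scatter), a change of no real size. For compound 4 the estimate is 30000 nM, with an expected range from 12000 nM to 64000 nM and a fair chance that only a limit is reported.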

Compound 4, half-maximal inhibitory concentration: 6590 nM
For compound 4 the middle estimate is 4.6-fold (0.66 log units) above the measured one, and the stated range ends above it.
By their numbers in this assay, from the lowest: compound 4; then compounds 2 and 3 (each within the scatter of the next). At a limit, above all of these: compound 1.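

This position, on an aromatic carbon para to a large group, responds to the exchange: in this assay, methyl in place of bromo gives an at least 4.8-fold lower number from compound 1 to compound 4 (0.68 log units; beyond the scatter). Among the compounds shown here, the read-out therefore moves from a limit to a number with one heavy atom exchanged for one heavy atom and with no ring, hydrogen-bond donor, hydrogen-bond acceptor or net charge entering or leaving, a sensitivity the earlier compounds could not show, as none of them differed from another in one place only. Compound 1 stands at a limit and not a number, so the full size of this step stays unknown: the limit of > 32000 nM in this assay, at which 1 of the 4 values shown sits.

One pair cannot tell whether the change in read-out follows from gaining methyl or from losing bromo, and a chloro, methoxy or ethyl group at this place, or an unsubstituted ring on the same core, would help to separate the two. Going by these compounds, whether the same exchange carries over to the core of compound 3, which has neither bromo nor methyl at this place, also remains open.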